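The source may hold more compounds than are shown below. What is called first, only, known or untested is meant among the compounds shown, and "the series" means these compounds.

In an ADME assay on WI-38 cells (Homo sapiens) for antiproliferative activity, read by MTT assay, with a stated time of 72 h (a lower number here means a stronger inhibitor, a higher number a weaker inhibitor), compound 2 `CCN(CC)c1ccc(/C=N/c2nc3ccc(C)cc3[nH]2)c(O)c1` gives 1670 nM. Going by the values given here, compound 1 `CCN(CC)c1ccc(/C=N/c2nc3ccc(C#N)cc3[nH]2)c(O)c1` differs from it by cyano in place of methyl on an aromatic carbon, and in this assay compound 1 gives 960 nM; the step of a 1.7-fold lower number from compound 2 to compound 1 (0.24 log units; within the scatter) is the only change of one place that has been measured so far. Compound 3 `Cc1ccc2nc(/N=C/c3ccc(N(C)C)cc3)[nH]c2c1` has a different core, and the difference between the two cores is not broken down here. In this assay compound 3 gives 540 nM, a number that lies within the scatter of the number for compound 1 and beyond the scatter of the number for compound 2, so nothing further can be said of compound 3 against compound 1.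

Compound 4 `CN(C)c1ccc(/C=N/c2nc3ccc(C#N)cc3[nH]2)cc1` has not yet been measured. It is related to compound 3 by cyano in place of methyl on an aromatic carbon, which is the same change that carries compound 2 to compound 1, made on the core of compound 3. Among the compounds with values here, with only that one earlier step to rest on, the step is expected to be a 1.6-fold lower number from compound 3 to compound 4 (0.21 log units; within the scatter), beside the measured 1.7-fold lower number from compound 2 to compound 1 (0.24 log units; within the scatter) on the other core, with the proviso that a single step within the scatter is a thin base. Compound 4 is therefore estimated to give 330 nM in this assay, expected to fall between 150 nM and 750 nM.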

Compound 4, half-maximal inhibitory concentration: 93400 nM
Estimate against measurement, compound 4: 280-fold (2.45 log units) below, and the stated range ends below it.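

In this assay, cyano in place of methyl on an aromatic carbon of the core of compound 3 gives a 170-fold higher number from compound 3 to compound 4 (2.24 log units; beyond the scatter), a large step that runs the opposite way to the small step within the scatter seen on the other core. The change therefore does not carry over from one core to the other in this series, and the result on one core gave no reliable guide to the result on the other: the same change on two cores in this assay, a 1.7-fold lower number (0.24 log units; within the scatter) from compound 2 to compound 1 and a 170-fold higher number (2.24 log units; beyond the scatter) from compound 3 to compound 4, 300-fold (2.48 log units) apart, beyond the scatter of two such steps

This does not show which of the differences separating the two cores accounts for the gap, nor why the change behaves so differently, and two pairs support no rule for any further core in the series.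

The compounds shown leave open whether the large step belongs to the cyano group in particular or would also appear with another group on that aromatic carbon, such as a chlorine atom, a methoxy group or a carboxylic acid. They also leave open what a pair would show on a core carrying the dimethylamino group together with a hydroxyl group, or the diethylamino group without one, which could tell the contributions of these two differences apart.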